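The source may report more compounds than this note shows. Statements on the series, on what has been measured and on what is new or still open speak of the compounds shown alone.

Compound 1 `COc1ccc(OC(=O)Nc2ccc([Se]C#N)cc2)cc1`: in a functional assay on PC-3 cells (Homo sapiens) for cytotoxicity, read by MTT assay, with a stated time of 72 h (on this read-out lower numbers stand for stronger inhibition of growth and higher numbers for weaker inhibition of growth), compound 1 gives 7500 nM.
Compound 2 `CCCOC(=O)Nc1ccc([Se]C#N)cc1`: in this assay compound 2 gives 21100 nM.
Compound 3 `N#C[Se]c1ccc(NC(=O)OCc2ccc([N+](=O)[O-])cc2)cc1`: in this assay compound 3 gives 9000 nM.

Within the data shown here, of the three numbers so far, compound 1 has the lowest. Compound 3 stands close to it, within the usual scatter of repeated measurements, so the two cannot be told apart on these data. Compound 2 gives a higher number, and that gap lies beyond the scatter. Compound 1 is therefore not set apart from compound 3, only from compound 2.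

The next step goes from compound 1 to compound 4 `Cc1ccc(OC(=O)Nc2ccc([Se]C#N)cc2)cc1`. The change is methyl in place of methoxy on an aromatic carbon. Among the measured compounds shown here, no measured pair in this set differs in that way, so there is no measured step to lean on; the shared core, the carbamate linkage and the aryl ester part all stay as they are in compound 1. On that basis a small step is expected in this assay, with no clear direction and none beyond the scatter. The step of a 1.1-fold higher number from compound 1 to compound 4 (0.03 log units; within the scatter) is the one estimated here. Compound 4 is expected to give about 8000 nM, with a range from 3500 nM to 18000 nM.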

Compound 4, concentration for 50% growth inhibition: 7600 nM
For compound 4 the middle estimate is 1.1-fold (0.02 log units) above the measured one, within the range that was stated.
By their numbers in this assay, from the lowest: compounds 1, 4 and 3 (each within the scatter of the next); then compound 2.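

Methyl in place of methoxy on this aromatic carbon, para to a large group, gives a 1.0-fold higher number from compound 1 to compound 4 (0.01 log units; within the scatter), the first step in the set that can be read at a single place. In this assay, among these compounds, the methoxy group can therefore give way to methyl here, losing its oxygen and its hydrogen-bond acceptor, with no difference that stands out from the usual scatter, something the earlier compounds, which differ from one another in more than one place, could not show. Nothing measured here offers an explanation for this flat step.

The compounds shown leave open whether this position would stay as flat with an amine, a carboxylic acid or a longer chain such as butoxy on the same carbon, or with only hydrogen there. With a single step at this place, they also leave open whether the flat result holds for other changes on this ring or is limited to the exchange of these two small groups.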